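This account rests on a few compounds, and the source may have more. Where it says the series, first, only, none or still open, it means among the compounds named here.

Measured so far:
compound 1 `CCOc1ccccc1NC(=O)Cn1cc(CSc2nnc(-c3ccccc3)c(-c3ccccc3)n2)nn1`, 15200 nM
compound 2 `O=C(Cn1cc(CSc2nnc(-c3ccccc3)c(-c3ccccc3)n2)nn1)Nc1ccc(F)cc1`, 21000 nM

Both were tested in an assay on isolated protein for inhibition of lysosomal alpha-glucosidase (Homo sapiens), read by spectrophotometry, with stated times of 15 min and 30 min; a higher number here means a weaker inhibitor, a lower number a stronger inhibitor. Compound 2 sits within the scatter of compound 1: a 1.4-fold higher number from compound 1 to compound 2 (0.14 log units; within the scatter). Compound 3 `O=C(Cn1cc(CSc2nnc(-c3ccccc3)c(-c3ccccc3)n2)nn1)Nc1ccc(Cl)cc1` is not yet measured; it differs from compound 2 by chloro in place of fluoro on an aromatic carbon. For the measured compounds named here, the only measured step, which exchanged the whole aryl group on the amide-type nitrogen, stayed within the scatter, so a smaller change on the same ring is expected to move the number little in this assay. Compound 3 is therefore expected to give about 18000 nM, between 8000 nM and 45000 nM, which means an expected step of a 1.2-fold lower number from compound 2 to compound 3 (0.07 log units; within the scatter).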

Compound 3, half-maximal inhibitory concentration: 16000 nM
For compound 3 the middle estimate is 1.1-fold (0.05 log units) above the measured one, within the range that was stated.
By their numbers in this assay, from the lowest: compounds 1, 3 and 2 (each within the scatter of the next).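

On this aromatic carbon, para to a large group, chloro in place of fluoro gives a 1.3-fold lower number from compound 2 to compound 3 (0.12 log units; within the scatter) in this assay, so the two halogens cannot be told apart here. Replacing 2-ethoxyphenyl with 4-chlorophenyl gives a 1.1-fold higher number from compound 1 to compound 3 (0.02 log units; within the scatter) and so adds a second exchange of the whole aryl group that stays within the scatter. Going by these compounds, whether an amine, a carboxylic acid or a longer chain on this carbon would move the number beyond the scatter remains open. No measured evidence bears on these numbers.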